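A few compounds are considered here, and "the series" means these few. Any claim that something is new, unique, unknown or untested is made for them only; others in the source may bear on it.

Of the compounds shown here, three built on a shared core have been tested in a functional assay on THP-1 cells (Homo sapiens) for inhibition, read by sulforhodamine B assay, with a stated time of 48 h, tested at 50 uM; a higher number here means more inhibition of growth at the concentration tested, a lower number less inhibition of growth. Compound 1 `O=C1C(=O)N(CCCn2cc(COc3cc(=O)oc4ccccc34)nn2)c2ccc(I)cc21` gives 67%. Compound 3 `O=C1C(=O)N(CCCCn2cc(COc3cc(=O)oc4ccccc34)nn2)c2ccc(Br)cc21` gives 63%, a number that lies within the usual scatter of the value for compound 1. Compound 2 `COc1ccc2c(c1)C(=O)C(=O)N2CCCCn1cc(COc2cc(=O)oc3ccccc23)nn1` gives 52%, and here the gap to compound 1 lies beyond the scatter. Compound 2 and compound 3 differ in one place, bromo in place of methoxy on an aromatic carbon, and that change brought a number 11 percentage points higher from compound 2 to compound 3 (beyond the scatter).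

Compound 4 `O=C1C(=O)N(CCCn2cc(COc3cc(=O)oc4ccccc34)nn2)c2ccc([N+](=O)[O-])cc21` has not yet been measured. It differs from compound 1 in one place: nitro in place of iodo on an aromatic carbon. For the measured compounds named here, the only measured step that bears on this is the one from compound 2 to compound 3, which also exchanged the group on an aromatic carbon of the core and was modest in size. Going by the values given here, no measured pair exchanges a halogen for a nitro group, so the direction of the change cannot be read from the data. For compound 4 the step is expected to be small, a number 7 percentage points lower from compound 1 to compound 4 (within the scatter), and may well stay within the scatter. Compound 4 is therefore estimated to give 60% in this assay, with a range from 45% to 75%.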

Compound 4, percent growth inhibition at one concentration: 60%
For compound 4 middle estimate and measured number coincide at the digits printed; the range from low to high includes it.
By their numbers in this assay, from the lowest: compounds 2, 4, 3 and 1 (each within the scatter of the next, the first and the last beyond it).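

Exchanging the one iodine atom for the three heavy atoms of a nitro group, with two hydrogen-bond acceptors where iodo has none, gave a number 7 percentage points lower from compound 1 to compound 4 (within the scatter) in this assay and so left growth inhibition within the scatter. On this aromatic carbon of the core, then, a single halogen and a larger group carrying acceptors are not told apart by this read-out, whereas the earlier exchange on an aromatic carbon of the core, a number 11 percentage points higher from compound 2 to compound 3 (beyond the scatter) with methoxy as the lower partner, did separate two groups. Nothing measured here accounts for either step.

The compounds shown leave open whether an amine or a carboxylic acid on this aromatic carbon would move the number beyond the scatter in this assay or whether plain hydrogen would. They also leave the chain unsettled: iodo and nitro sit on a shorter chain, bromo and methoxy on a longer one, and no pair shown differs in the chain alone, so what a longer chain would do to compound 4 cannot be judged.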